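The compounds below may be only part of what the source reports. "The series", "measured", "known", "first", "only" and "open" are said of these compounds alone.

In a functional assay on KB cells (Homo sapiens) for antiproliferative activity, read by colorimetric assay and MTT assay (on this read-out higher numbers stand for weaker inhibition and lower numbers for stronger inhibition), three compounds have been measured. Compound 1 `COc1ccc(S(=O)(=O)Nc2cccc3cc[nH]c23)cc1` gives 0.67 ug/mL, compound 2 `COc1ccc(S(=O)(=O)Nc2ccc(Cl)c3cc[nH]c23)cc1` gives 0.92 ug/mL, and compound 3 `O=S(=O)(Nc1cccc2cc[nH]c12)c1ccc(Cl)cc1` gives 6 ug/mL. Compound 3 therefore has the highest number of the three and is the weakest inhibitor among them. Compound 4 `O=S(=O)(Nc1cccc2c(Cl)c[nH]c12)c1ccc(Cl)cc1` has not yet been measured. It differs from compound 3 in a single place: chloro in place of hydrogen on an aromatic carbon.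

Two measured steps offer some guidance. The first, a 9.0-fold higher number from compound 1 to compound 3 (0.95 log units; beyond the scatter), is modest and beyond the scatter, but it exchanges methoxy for chloro, which is a different change and says little about this one. The second is closer in kind, as it also puts chloro in place of hydrogen on an aromatic carbon, though at another place on the core and in a compound carrying methoxy. Going by a 1.4-fold higher number from compound 1 to compound 2 (0.14 log units; within the scatter), no step beyond the scatter is expected in this assay, although this rests on a single comparison. The estimated change is a 1.5-fold lower number from compound 3 to compound 4 (0.18 log units; within the scatter). Compound 4 is expected at 4 ug/mL, with an estimated range from 1 ug/mL to 12 ug/mL.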

Compound 4, half-maximal inhibitory concentration: 8.8 ug/mL
The estimate for compound 4 lay 2.2-fold (0.34 log units) below the measured number; low and high end bracket the measured number.
By their numbers in this assay, from the lowest: compounds 1 and 2 (each within the scatter of the next); then compounds 3 and 4 (each within the scatter of the next).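

The chloro on an aromatic carbon of the five-membered aromatic ring, two ring bonds from the ring nitrogen, is the first substitution shown at this position, and in this assay it gives a 1.5-fold higher number from compound 3 to compound 4 (0.17 log units; within the scatter). Hydrogen at this place can therefore be exchanged for chloro, on a core that carries chloro rather than methoxy, without a step beyond the scatter; compound 2 alone could not show this, as its chloro stands at a different place and its core carries methoxy. The two chloro steps, at different places and on different cores, agree in size: the same change on two cores in this assay, a 1.4-fold higher number (0.14 log units; within the scatter) from compound 1 to compound 2 and a 1.5-fold higher number (0.17 log units; within the scatter) from compound 3 to compound 4, 1.1-fold (0.03 log units) apart, within the scatter of two such steps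

Only hydrogen and chloro are shown at this position, so what an amine, a carboxylic acid or a longer chain there would do in this assay remains open. Also open, on these data alone, is whether chloro at this same position would stay within the scatter on the methoxy-bearing core of compound 1, and whether the step would hold in any other assay.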